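Spiro-oxindole series: aromatic substituent swap on the triazole aryl

The source may report more compounds than this note shows. Statements on the series, on what has been measured and on what is new or still open speak of the compounds shown alone.

Measured so far:
Compound 1 `N#CC1=C(N)Oc2c(c3nc4ccccc4nc3c3ccccc23)C12C(=O)N(Cc1cnnn1-c1ccccc1Cl)c1ccccc12` — in an ADME assay on HUVEC cells (Homo sapiens) for antiproliferative activity, read by MTT assay, with a stated time of 48 h (on this read-out lower numbers stand for stronger inhibition and higher numbers for weaker inhibition), compound 1 gives a limit, > 50000 nM.
Compound 2 `N#CC1=C(N)Oc2c(c3nc4ccccc4nc3c3ccccc23)C12C(=O)N(Cc1cnnn1-c1ccc(Br)cc1)c1ccccc12` — in this assay compound 2 gives a limit, > 50000 nM.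
Compound 3 `CCc1ccccc1-n1nncc1CN1C(=O)C2(C(C#N)=C(N)Oc3c(N)cc4nc5ccccc5nc4c32)c2ccccc21` — in this assay compound 3 gives a limit, > 50000 nM.

Compound 3 stands where every value shown so far stands: at the limit of this assay, with no number below it. Among the compounds with values here, the only single-place step among the measured compounds, a step that the two limits leave unreadable from compound 1 to compound 2, is unreadable, since both ends are limits.

Compound 4 `N#CC1=C(N)Oc2c(N)cc3nc4ccccc4nc3c2C12C(=O)N(Cc1cnnn1-c1ccccc1Cl)c1ccccc12` differs from compound 3 by chloro in place of ethyl on an aromatic carbon. Within the data shown here, no measured step bears on this change, and the one step that exists carries no readable size. The expected step, a number no higher from compound 3 to compound 4 (the limit leaves the size open), is therefore none beyond the scatter, because all three values shown sit at the limit of > 50000 nM in this assay, at which 3 of the 3 values shown sit. Compound 4 is estimated to return a limit again rather than a number. For compound 4 the estimated value is 50000 nM, with a range from 20000 nM to 150000 nM.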

Compound 4, half-maximal inhibitory concentration: > 50000 nM
Compound 4 gave a limit, no number; the forecaster's own chance of this, stated with the estimate: 85%; the middle value lies on the limit itself.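

No step can be read for chloro in place of ethyl, since compound 3 and compound 4 both give only a limit and not a number: the limit of > 50000 nM in this assay, at which 4 of the 4 values shown sit.

The compounds shown leave open whether any of these aryl substituent changes alters the read-out at all.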